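A few compounds are considered here, and "the series" means these few. Any claim that something is new, unique, unknown or untested is made for them only; others in the source may bear on it.

Working notes on the series around the core of compound 2 `COc1ccc(-c2cnc(NC(=O)c3cccc(Br)c3)n2C)cc1`. In a toxicity assay on THP-1 cells (Homo sapiens) for inhibition (a higher number here means that more compound is tolerated, a lower number that less compound is tolerated), compound 2 reaches only the assay limit, > 100000 nM, and gives no number. Compound 1 `Cn1c(-c2ccccc2)cnc1NC(=O)c1ncc[nH]1` likewise stops at a limit, > 100000 nM, in this assay. Compound 3 `Cn1c(-c2ccccc2)cnc1NC(=O)c1cccc(Br)c1` stops at the limit > 50000 nM in this assay. Both measured steps, a step that the two limits leave unreadable from compound 1 to compound 3 and a step that the two limits leave unreadable from compound 2 to compound 3, stay unreadable because the limit of > 100000 nM in this assay, at which 2 of the 3 values shown sit, and the limit of > 50000 nM in this assay, at which 1 of the 3 values shown sits, bound them on either side. Compound 4 `COc1ccc(-c2cnc(NC(=O)c3cccc(Cl)c3)n2C)cc1` is not yet measured; it differs from compound 2 by chloro in place of bromo on an aromatic carbon. Going by the values given here, no measured step bears on this change, so no direction beyond the scatter can be read. Compound 4 is estimated at 100000 nM in this assay, between 50000 nM and 200000 nM. The expected step is a number no higher from compound 2 to compound 4 (the limit leaves the size open).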

Compound 4, half-maximal cytotoxic concentration: > 28000 nM
Compound 4 ended at the assay's limit (the forecaster's own chance of this, stated with the estimate: 85%); the middle value does not contradict the limit.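

Going by these compounds alone, compound 2 and compound 4 both stop at assay limits in this assay, and no step between them can be read. The compounds shown leave open whether chloro in place of bromo changes the tolerated concentration at all.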